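Chromene esters: aryl substituent exchange at the fused ring

The compounds below may be only part of what the source reports. "The series", "measured", "known", "first", "only" and "open" are said of these compounds alone.

Measured compounds:
- compound 1 `COC(=O)CC1C(C(=O)OC)=C(N)Oc2ccc(-c3cc(OC)cc(OC)c3)cc21`: 2420 nM
- compound 2 `C=CCOC(=O)CC1C(C(=O)OCC=C)=C(N)Oc2ccc(-c3cc(OC)cc(OC)c3)cc21`: 4700 nM
- compound 3 `CCOC(=O)CC1C(C(=O)OCC)=C(N)Oc2ccc(-c3ccccc3F)cc21`: 73000 nM

All three were run in a functional assay on HL-60 cells (Homo sapiens) for cytotoxicity, read by CellTiter-Blue, with a stated time of 48 h; on this read-out lower numbers stand for stronger inhibition and higher numbers for weaker inhibition. Compound 1 gives 2420 nM and compound 2 gives 4700 nM; these two share the same aryl group and differ in the ester, and their values lie within the usual scatter of one another. Compound 3, which carries different esters and a different aryl group, gives 73000 nM, the highest number of the three, beyond the scatter from both compound 2 and compound 1. For the measured compounds named here, no pair here differs in a single place, so the contributions of the ester and the aryl group cannot be separated on these data.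

Compound 4 `CCOC(=O)CC1C(C(=O)OCC)=C(N)Oc2ccc(-c3cccc(NC)c3)cc21` keeps the esters of compound 3 and changes only the aryl group: 3-(methylamino)phenyl in place of 2-fluorophenyl on an aromatic carbon.

Going by the values given here, no measured pair reports this step. With compounds 1 and 2 showing lower numbers than compound 3 under a different aryl group, the aryl group is where the remaining spread appears to sit, and a move toward lower numbers is expected, though with wide uncertainty. For compound 4 the estimated step from compound 3 is a 4.9-fold lower number from compound 3 to compound 4 (0.69 log units; beyond the scatter) in this assay, in the direction of a lower number.

Compound 4 is estimated at 15000 nM, with a range from 3000 nM to 60000 nM.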

Compound 4, half-maximal inhibitory concentration: 7450 nM
Beside the measured number, compound 4's estimate is 2.0-fold (0.30 log units) above it; low and high end bracket the measured number.
By their numbers in this assay, from the lowest: compounds 1, 2 and 4 (each within the scatter of the next, the first and the last beyond it); then compound 3.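

For the compounds shown here, with the esters of compound 3 held fixed, placing 3-(methylamino)phenyl in place of 2-fluorophenyl on the aromatic carbon gives in this assay a 9.8-fold lower number from compound 3 to compound 4 (0.99 log units; beyond the scatter) as the first single-place step. The earlier compounds shown here could not separate the ester from the aryl group, whereas this step shows that the aryl group alone can move the number beyond the scatter, at least for this one exchange with these esters. No measurement at hand bears on the reason for this step.

On these data alone, the step swaps the fluorine for a methylamino group and also changes the name-given ring position of the substituent, so it remains open whether the lower number goes with the arrival of the nitrogen group, the departure of the fluorine, or the change of position. Plain phenyl, 3-aminophenyl, 3-(dimethylamino)phenyl or 3-fluorophenyl on the same esters would separate these readings, and the aryl group of compound 1 carried on those esters would give a first single-place reading of the ester's share.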